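From Methoxy to Chloro: Expecting a Plasma Half-Life

The source may hold more compounds than are shown below. What is called first, only, known or untested is meant among the compounds shown, and "the series" means these compounds.

Compound 1 `COc1cc(Oc2ncc(C)s2)cc(-c2ccc3c(c2)CC[C@H](CCC(=O)O)O3)c1F` has been tested in an ADME assay on the whole organism (plasma, Rattus norvegicus) for metabolic stability, read by LC-MS, at a dose of 0.1 mg/kg by the intravenous route (a higher number here means that the compound lasts longer, a lower number that the compound disappears faster), where compound 1 gives 1.2 h. Its companion compound 2 `O=C(O)CC[C@H]1CCc2cc(-c3nc(OC4CCC4)ccc3F)ccc2O1` gives 0.74 h in this assay; the two numbers lie within the usual scatter of repeated measurements, so neither compound can be called the longer-lasting one. Compound 3 `Cc1cnc(Oc2cc(Cl)c(F)c(-c3ccc4c(c3)CC[C@H](CCC(=O)O)O4)c2)s1` is not yet measured. It differs from compound 1 by chloro in place of methoxy on an aromatic carbon. For the measured compounds named here, no measured pair shows what this change does on its own, so the expectation rests on compound 1 alone. For compound 3 the expected half-life is 1.4 h, with a range from 0.7 h to 2.8 h. The estimated step of a 1.2-fold higher number from compound 1 to compound 3 (0.07 log units; within the scatter) is therefore small, not beyond the scatter in either direction.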

Compound 3, half-life: 0.93 h
Estimate against measurement, compound 3: 1.5-fold (0.18 log units) above; low and high end bracket the measured number.
By their numbers in this assay, from the lowest: compounds 2, 3 and 1 (each within the scatter of the next).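

Chloro in place of methoxy on this aromatic carbon, ortho to a fluoro group, gives a 1.3-fold lower number from compound 1 to compound 3 (0.11 log units; within the scatter) in this assay. For the compounds shown here, this is the first single-place change seen here, and it shows that the half-life cannot tell these two groups apart at this position. On these data alone, whether an amine or a nitrile on the same carbon would also give a half-life within the scatter of compound 1 remains open. Nothing measured on these compounds offers an explanation for this result.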